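A Methoxy-to-Hydroxy Swap Carried Onto a Second Core

This account rests on a few compounds, and the source may have more. Where it says the series, first, only, none or still open, it means among the compounds named here.

Compound 1 `COc1cc(-c2nn(-c3cccc(NC(=O)Nc4cc(C(F)(F)F)cc(C(F)(F)F)c4)c3)cc2-c2ccncc2)ccc1Cl` is the reference point. In a functional assay on OVCAR-5 cells (Homo sapiens) for inhibition, read by sulforhodamine B assay, with a stated time of 48 h (a higher number here means a weaker inhibitor of growth, a lower number a stronger inhibitor of growth), compound 1 gives 937 nM. Compound 2 `O=C(Nc1cccc(-n2cc(-c3ccncc3)c(-c3ccc(Cl)c(O)c3)n2)c1)Nc1cc(C(F)(F)F)cc(C(F)(F)F)c1` shares the core of compound 1 and carries hydrogen in place of methyl on an oxygen on an aromatic ring; in this assay compound 2 gives 875 nM. The measured step is a 1.1-fold lower number from compound 1 to compound 2 (0.03 log units; within the scatter). Compound 3 `COc1cc(-c2nn(-c3cccc(NC(=O)Nc4ccc(Cl)c(C(F)(F)F)c4)c3)cc2-c2ccncc2)ccc1Cl` rests on a different core; how that core differs from the core of compound 1 is not broken down here. In this assay compound 3 gives 3090 nM, the highest of the three numbers, and its distance from both compound 1 and compound 2 lies beyond the scatter. Compound 4 `O=C(Nc1cccc(-n2cc(-c3ccncc3)c(-c3ccc(Cl)c(O)c3)n2)c1)Nc1ccc(Cl)c(C(F)(F)F)c1` has not yet been measured and is related to compound 3 by hydrogen in place of methyl on an oxygen on an aromatic ring. The surroundings of the place are the same word for word in both pairs, so this is the same change already made from compound 1 to compound 2. Because the step of a 1.1-fold lower number from compound 1 to compound 2 (0.03 log units; within the scatter) lies within the scatter, the step expected in this assay is a 1.1-fold lower number from compound 3 to compound 4 (0.04 log units; within the scatter). Compound 4 is therefore estimated at 2800 nM in this assay, with a likely range from 1400 nM to 5600 nM.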

Compound 4, concentration for 50% growth inhibition: 1570 nM
Estimate against measurement, compound 4: 1.8-fold (0.25 log units) above, and the stated range covers the measured number.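

In this assay, the swap of methoxy to hydroxy, from 4-chloro-3-methoxyphenyl to 4-chloro-3-hydroxyphenyl, gives a 2.0-fold lower number from compound 3 to compound 4 (0.29 log units; within the scatter). Set beside the same swap on the core of compound 1, the step on the second core does not differ measurably from the first: the same change on two cores in this assay, a 1.1-fold lower number (0.03 log units; within the scatter) from compound 1 to compound 2 and a 2.0-fold lower number (0.29 log units; within the scatter) from compound 3 to compound 4, 1.8-fold (0.26 log units) apart, within the scatter of two such steps On these two pairs the swap carries from one core to the other and moves the number by no more than the scatter on either core, but this does not show that the hydroxy compounds are stronger inhibitors of growth, and two cores say nothing about how the swap would behave on a third.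

The compounds shown leave open what other groups on that oxygen would give, such as an ethyl group or an acetyl group in place of the methyl or the hydrogen. They also leave open whether an amine in place of the hydroxy, or a fluoro group in place of the chloro, would keep the two cores in step.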